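Propylsulfonyl to Ethylsulfanyl: What Compound 4 Might Show

This account rests on a few compounds, and the source may have more. Where it says the series, first, only, none or still open, it means among the compounds named here.

Measured in a functional assay for agonist activity at Glucose-dependent insulinotropic receptor (Homo sapiens); on this read-out lower numbers stand for an effect already at smaller amounts and higher numbers for an effect only at larger amounts of compound:
compound 1 `Cc1noc(C2CCN(c3ncnc(Nc4ccc(S(C)(=O)=O)cc4)c3[N+](=O)[O-])CC2)n1` gives 260 nM
compound 2 `CS(=O)(=O)c1ccc(Nc2ncnc(N3CCC(c4nc(-c5cccc(C(F)(F)F)c5)no4)CC3)c2[N+](=O)[O-])cc1` gives 24 nM
compound 3 `CCCS(=O)(=O)c1ccc(Nc2ncnc(N3CCC(c4nc(C(C)C)no4)CC3)c2[N+](=O)[O-])cc1` gives 4.7 nM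

Compound 3 stands lowest of the three numbers in this assay; compound 2 is the nearest and compound 1 the furthest, both gaps beyond the scatter. Compound 4 `CCSc1ccc(Nc2ncnc(N3CCC(c4nc(C(C)C)no4)CC3)c2[N+](=O)[O-])cc1` has not yet been measured. It differs from compound 3 in one place: ethylsulfanyl in place of propylsulfonyl on an aromatic carbon. For the measured compounds named here, the only measured step, an 11-fold lower number from compound 1 to compound 2 (1.03 log units; beyond the scatter), concerns a different position, so no measured step bears directly on this exchange. Without a guide, the expected step for compound 4 is a 3.2-fold higher number from compound 3 to compound 4 (0.50 log units; beyond the scatter), toward a higher number, of a size that may or may not exceed the scatter. Compound 4 is thus estimated at 15 nM in this assay, within 3 nM to 70 nM.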

Compound 4, half-maximal effective concentration: 110 nM
For compound 4 the middle estimate is 7.3-fold (0.87 log units) below the measured one, outside the stated range (above it).
By their numbers in this assay, from the lowest: compound 3; then compound 2; then compound 4; then compound 1.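

In this assay, the position para to a large group proves highly sensitive: replacing propylsulfonyl with ethylsulfanyl gives a 23-fold higher number from compound 3 to compound 4 (1.37 log units; beyond the scatter). For the compounds shown here, the earlier compounds held no step at this place, so this is the first sign that the read-out responds strongly to what sits there. No evidence at hand says what lies behind this step, or whether the sulfur group or the chain carries it.

The compounds shown leave open where ethylsulfonyl or propylsulfanyl would fall relative to compound 3 and compound 4. They also leave open how a carboxylic acid or an amine would read at this position.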